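A few compounds are considered here, and "the series" means these few. Any claim that something is new, unique, unknown or untested is made for them only; others in the source may bear on it.

For the measured compounds named here, in an assay on HEK293 cells for agonist activity at transient receptor potential cation channel subfamily M member 8 (Homo sapiens), read by fluorescence and calcium flux, with a stated time of 15 min (a higher number here means that more compound is needed for the effect, a lower number that less compound is needed), compound 1, `C=CCN(Cc1cccs1)C(=O)COc1ccc(C)cc1`, gives 20 nM, the second highest of the three numbers measured so far. Compound 2, `CCN(Cc1cccs1)C(=O)COc1ccc(C)cc1O`, gives 8 nM, and compound 3, `CCN(Cc1cccs1)C(=O)COc1ccc2c(c1)COC2`, gives 61 nM. The gap between compound 1 and each of these lies beyond the usual scatter, yet each pair differs in more than one place, so no single change can be read from them. Compound 4, `Cc1ccc(OCC(=O)N(Cc2cccs2)c2cnccn2)cc1`, is not yet measured. It differs from compound 1 in one place: pyrazin-2-yl in place of allyl on an amide-type nitrogen. Going by the values given here, no measured pair shows a change of this kind, so the direction is uncertain, and a modest rise in the number, toward less potent, is expected as the step of a 2.5-fold higher number from compound 1 to compound 4 (0.40 log units; beyond the scatter). Compound 4 is therefore expected to give about 50 nM, within a range from 10 nM to 250 nM.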

Compound 4, half-maximal effective concentration: 1240 nM
The estimate for compound 4 lay 25-fold (1.39 log units) below the measured number, outside the stated range (above it).
By their numbers in this assay, from the lowest: compound 2; then compound 1; then compound 3; then compound 4.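

Putting pyrazin-2-yl in place of allyl on the amide-type nitrogen brings a 62-fold higher number from compound 1 to compound 4 (1.79 log units; beyond the scatter) in this assay, a large step. This is the first change in a single place among these compounds, and it shows that the group on this nitrogen can strongly shift the concentration needed. Nothing measured here explains why the step is so large. Still open, on these data alone, is whether the six-membered ring itself or its two nitrogen atoms matter more, and how a phenyl ring or a propyl chain would fare on this nitrogen.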